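Compound 4: a methylphenyl in place of a chlorophenyl

The source may report more compounds than this note shows. Statements on the series, on what has been measured and on what is new or still open speak of the compounds shown alone.

Measured so far, in a functional assay on the whole organism (strain Wistar) for inhibition, with Rattus norvegicus as the target, read by paw edema, with a stated time of 4 h, at a dose of 10 mg/kg by the oral route; a higher number here means more inhibition at the dose given (going by the name of the read-out), a lower number less inhibition:
compound 1 `Clc1ccccc1-c1nnc(COc2ccc(-c3ccccc3)cc2)o1` gives 63.6%
compound 2 `Fc1ccc(-n2c(S)nnc2COc2ccc(-c3ccccc3)cc2)cc1` gives 79.5%
compound 3 `Clc1ccc(Nc2nnc(COc3ccc(-c4ccccc4)cc3)s2)cc1` gives 54.5%

Of these three numbers, compound 3 gives the lowest, yet the gap to compound 1 lies within the usual scatter of repeated measurements; only compound 2 stands beyond it.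

Compound 4 `Cc1ccccc1Nc1nnc(COc2ccc(-c3ccccc3)cc2)s1` is the next compound to be tested in this assay. It differs from compound 3 in one place: 2-methylphenyl in place of 4-chlorophenyl on a nitrogen on an aromatic ring. Among the measured compounds shown here, no measured pair shows a change of this kind, so the size of its effect cannot be read from the numbers at hand. A step from compound 3 to compound 4 of about a number 0.5 percentage points higher from compound 3 to compound 4 (within the scatter) is expected, none beyond the scatter in either direction. Compound 4 is therefore estimated to give 55%, in a range from 40% to 70%.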

Compound 4, a percentage reported as inhibition, in the whole organism at one dose (the size of the read-out at that dose, not a potency): 29.5%
Beside the measured number, compound 4's estimate is 25.5 percentage points above it, outside the stated range (below it).
By their numbers in this assay, from the lowest: compound 4; then compounds 3 and 1 (each within the scatter of the next); then compound 2.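

In this assay, placing 2-methylphenyl where 4-chlorophenyl stood gives a number 25 percentage points lower from compound 3 to compound 4 (beyond the scatter), so the group on this nitrogen matters to the result. The two groups match in heavy atoms and in hydrogen-bond donors and acceptors, so those counts do not separate them. Nothing available bears on why the number falls. The change swaps both the kind of group on the ring and its place, and the compounds shown cannot tell these apart. Comparing 4-methylphenyl or 2-chlorophenyl on the same nitrogen would separate the two.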